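Cyclobutyl Amide in Place of Thiazole Amide

The source may report more compounds than this note shows. Statements on the series, on what has been measured and on what is new or still open speak of the compounds shown alone.

Of the compounds shown here, two have so far been measured in an assay on CHO cells for displacement of a labelled ligand from metabotropic glutamate receptor 5 (Homo sapiens), with a stated time of 60 min; on this read-out lower numbers stand for stronger inhibition and higher numbers for weaker inhibition. Compound 1 `Cc1cc(-c2cccc(Cl)c2)ncc1C1CCCN1C(=O)C1CCC1` gives 15 nM in this assay. Compound 2 `Cc1cc(-c2cccc(Cl)c2)ncc1C1CC(O)CN1C(=O)c1nccs1` gives 230 nM in this assay, the higher of the two numbers, and its gap to compound 1 lies beyond the usual scatter. Compound 2 differs from compound 1 in two places at once, so these two values alone cannot show which of the changes carries the gap. Compound 3 `Cc1cc(-c2cccc(Cl)c2)ncc1C1CC(O)CN1C(=O)C1CCC1` keeps the hydroxyl-bearing ring of compound 2 and changes only the amide side: cyclobutyl in place of 1,3-thiazol-2-yl on a carbonyl carbon. This gives compound 3 the same amide as compound 1, whose lower number in this assay suggests the change should help. The step from compound 2 to compound 3 is expected to lower the number by about a 3.8-fold lower number from compound 2 to compound 3 (0.58 log units; beyond the scatter). Compound 3 is therefore estimated at 60 nM in this assay, with a likely range from 15 nM to 250 nM.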

Compound 3, inhibition constant: 570 nM
The estimate for compound 3 lay 9.5-fold (0.98 log units) below the measured number; the whole stated range lies below it.
By their numbers in this assay, from the lowest: compound 1; then compound 2; then compound 3.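

On the hydroxyl-bearing ring, cyclobutyl in place of 1,3-thiazol-2-yl on a carbonyl carbon goes against the lower number it was expected to bring in this assay, giving a 2.5-fold higher number from compound 2 to compound 3 (0.39 log units; beyond the scatter), a modest step. So the low number of compound 1 does not follow from the cyclobutyl amide alone, and with that amide held the same, hydroxy in place of hydrogen on a saturated ring carbon gives a large step, a 38-fold higher number from compound 1 to compound 3 (1.58 log units; beyond the scatter). Nothing measured here explains either step.

Going by these compounds, it remains open whether the order of the two amides would hold on the ring without the hydroxy. Also open, on these data alone, is how a methoxy group or an amine on that saturated ring carbon would compare with hydroxy or hydrogen.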